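Aryl thioether variation on the benzamide series

A few compounds are considered here, and "the series" means these few. Any claim that something is new, unique, unknown or untested is made for them only; others in the source may bear on it.

Of the compounds shown here, two have been measured in a functional assay on A-375 cells (Homo sapiens) for inhibition, read by CCK-8 assay, with a stated time of 72 h, tested at 2 uM; on this read-out higher numbers stand for more inhibition of growth at the one concentration tested and lower numbers for less inhibition of growth. Compound 1 `CCc1ccc(SCc2ccc(C(=O)Nc3ccccc3N)cc2)cc1` gives 19.6% and stands lowest of the two numbers. Compound 2 `Nc1ccccc1NC(=O)/C=C/c1ccc(CSCCc2ccccc2)cc1` gives 41.9% in this assay, a number higher than that of compound 1 by more than the scatter. Compound 3 `Cc1cc(C)cc(SCc2ccc(C(=O)Nc3ccccc3N)cc2)c1` is not yet measured; it differs from compound 1 as follows: 3,5-dimethylphenyl in place of 4-ethylphenyl on a sulfur. Among the compounds with values here, no measured pair differs in one place, so nothing shows how such a change moves the read-out. The step is expected to be small, within the scatter, in no fixed direction. Compound 3 is expected to give 22% (range 8% to 38%), an estimated step of a number 2.4 percentage points higher from compound 1 to compound 3 (within the scatter) in this assay.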

Compound 3, percent growth inhibition at one concentration: 48.5%
Compound 3: the middle estimate sits 26.5 percentage points below what was measured; measured number outside the range, above it.
By their numbers in this assay, from the lowest: compound 1; then compounds 2 and 3 (each within the scatter of the next).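

In this assay, 3,5-dimethylphenyl in place of 4-ethylphenyl on a sulfur gives a number 28.9 percentage points higher from compound 1 to compound 3 (beyond the scatter). Compound 1 and compound 3 hold the same atoms, joined differently, so the read-out at this position depends on how those carbons are arranged and not only on which atoms are present. Nothing available explains the step. Still open, from the compounds shown here alone, is whether the same change moves the read-out on the core of compound 2. Going by these compounds, the read-out with 3,5-dichlorophenyl or 3,5-dimethoxyphenyl on the sulfur also remains open.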